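Swapping the benzylic ring substituent in a sulfonamide series

A few compounds are considered here, and "the series" means these few. Any claim that something is new, unique, unknown or untested is made for them only; others in the source may bear on it.

Two compounds in this set share a core, a sulfonamide joined through a three-carbon chain to an amine that carries a benzyl group. Compound 1 `CC(C)(C)c1ccc(CNCCCNS(=O)(=O)c2cc(C(F)(F)F)cc(C(F)(F)F)c2)cc1` carries tert-butyl on that benzyl ring, and in a functional assay on MCF7 cells (Homo sapiens) for inhibition, read by MTT assay, with a stated time of 72 h (a lower number here means a stronger inhibitor of growth, a higher number a weaker inhibitor of growth), compound 1 gives 2100 nM. Compound 2 `O=S(=O)(NCCCNCc1ccc(C(F)(F)F)cc1)c1cc(C(F)(F)F)cc(C(F)(F)F)c1` carries trifluoromethyl in its place, and in this assay compound 2 gives 1400 nM. That single change gave a 1.5-fold lower number from compound 1 to compound 2 (0.18 log units; within the scatter), so the two numbers cannot be told apart, and compound 2 simply stands as the lower of the two, with compound 1 nearest to it.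

Compound 3 `O=S(=O)(NCCCNCc1cccc(Cl)c1)c1cc(C(F)(F)F)cc(C(F)(F)F)c1` changes the same benzyl ring again: 3-chlorophenyl in place of 4-(trifluoromethyl)phenyl on a saturated chain carbon bound to an amine nitrogen. For the measured compounds named here, the only step that bears on it is the one from compound 1 to compound 2, and that step stayed inside the scatter. On that basis no step beyond the scatter is expected in this assay, in either direction, and the expected step is a 1.1-fold higher number from compound 2 to compound 3 (0.03 log units; within the scatter). Compound 3 is therefore estimated at 1500 nM, with a range from 600 nM to 4000 nM.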

Compound 3, concentration for 50% growth inhibition: 2600 nM
Compound 3: middle estimate off by 1.7-fold (0.24 log units), on the low side; the range from low to high includes it.
By their numbers in this assay, from the lowest: compounds 2, 1 and 3 (each within the scatter of the next).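

The benzyl ring can now be changed more widely without a readable effect in this assay: 3-chlorophenyl in place of 4-(trifluoromethyl)phenyl gives a 1.9-fold higher number from compound 2 to compound 3 (0.27 log units; within the scatter), and 3-chlorophenyl in place of 4-(tert-butyl)phenyl gives a 1.2-fold higher number from compound 1 to compound 3 (0.09 log units; within the scatter). This change goes further than the earlier one, since the ring substituent is replaced and its printed ring number also changes from 4 to 3, and the group that enters has fewer heavy atoms than the 4-(trifluoromethyl)phenyl group that leaves, yet all three compounds remain within the scatter of one another. Nothing among the available data explains why these different rings give numbers that cannot be told apart.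

The 3-chlorophenyl change alters the substituent and its ring number together, so a 4-chlorophenyl or 3-(trifluoromethyl)phenyl group would be needed to separate the two effects. Going by these compounds, it also remains open whether a more different group on this ring, such as a carboxylic acid or an amine, or a longer chain between the sulfonamide and the amine, would move the number beyond the scatter.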